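Remote Aromatic Swap and the Acid Dissociation Constant

A few compounds are considered here, and "the series" means these few. Any claim that something is new, unique, unknown or untested is made for them only; others in the source may bear on it.

Measured compounds:
compound 1 `COc1ccc(Oc2ccc3c(NCCCNCc4cc(F)ccc4OC)ccnc3c2)cc1` — 9.28
compound 2 `COc1ccc(Oc2ccc3c(NCCCNCc4ccco4)ccnc3c2)cc1` — 9.28

In a physicochemical assay for acid dissociation, compound 1 gives 9.28, and compound 2 gives 9.28; the two stand level at the digits shown. For the measured compounds named here, the one step recorded, no change at the digits printed from compound 1 to compound 2 (within the scatter), swaps furan-2-yl for 5-fluoro-2-methoxyphenyl on a saturated chain carbon bound to an amine nitrogen and leaves the read-out unchanged within the scatter.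

Compound 3 `COc1ccc(F)cc1CNCCCNc1ccnc2cc(Cc3ccccc3)ccc12` has not yet been measured. It differs from compound 1 as follows: benzyl in place of 4-methoxyphenoxy on an aromatic carbon. The group concerned sits on an aromatic carbon of the fused two-ring system, far from the chain amine. Going by the values given here, the only measured step bears on it indirectly, since a change on the chain itself produced no shift. A step of no size beyond the scatter is therefore expected in this assay, namely a number 0.03 log units lower from compound 1 to compound 3 (within the scatter). Compound 3 is estimated at 9.25, within 8.95 to 9.55.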

Compound 3, acid dissociation constant: 9.47
Estimate against measurement, compound 3: 0.22 log units below; the measured number falls inside the stated range.
By their numbers in this assay, from the lowest: compounds 1, 2 and 3 (each within the scatter of the next).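

In this assay the aromatic carbon of the shared core now has a step of its own: benzyl in place of 4-methoxyphenoxy gives a number 0.19 log units higher from compound 1 to compound 3 (within the scatter) and so, like the earlier swap on the chain, stays inside the scatter. The entering benzyl has 7 heavy atoms and 0 hydrogen-bond acceptors against 9 and 2 for the group it replaces, so a difference in these counts at this place goes with no step beyond the scatter in compounds 1 and 3. Nothing measured here accounts for the size of this step.

The compounds shown leave open whether an amine or a carboxylic acid on this aromatic carbon would give a step beyond the scatter. On the chain, a piperidine in place of furan-2-yl remains an open case as well.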